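This account rests on a few compounds, and the source may have more. Where it says the series, first, only, none or still open, it means among the compounds named here.

Compound 1, `COc1ccc(N(C)c2nc(C)nc3ccccc23)cc1OCCN`, is studied in a functional assay on RKO cells (Homo sapiens) for inhibition, read by MTT assay, with a stated time of 48 h (a higher number here means a weaker inhibitor, a lower number a stronger inhibitor), where compound 1 gives 343 nM. Of the two compounds measured, compound 1 has the higher number; compound 2, `C[Se]c1ccc(N(C)c2nc(C3CC3)nc3ccccc23)cc1`, gives 21 nM and is the stronger inhibitor, a gap that lies beyond the scatter. Compound 3, `COc1ccc(N(C)c2nc(C)nc3ccccc23)cc1OCCCCC[Se]C#N`, differs from compound 1 by a group of 6 heavy atoms (4 carbon, 1 nitrogen, 1 selenium; no ring) in place of one nitrogen atom, on a saturated chain carbon, two bonds along the chain from an oxygen on an aromatic ring. For the measured compounds named here, no measured pair matches this change, so only a modest shift toward a lower number is expected, the step of a 2.3-fold lower number from compound 1 to compound 3 (0.36 log units; beyond the scatter) estimated to sit near the edge of the scatter. Compound 3 is thus expected to give about 150 nM, with a range from 50 nM to 500 nM.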

Compound 3, half-maximal inhibitory concentration: 3560 nM
Compound 3: middle estimate off by 24-fold (1.38 log units), on the low side; measured number above the stated range.
By their numbers in this assay, from the lowest: compound 2; then compound 1; then compound 3.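

In this assay, the group of 6 heavy atoms in place of the nitrogen atom on this saturated chain carbon gives a 10-fold higher number from compound 1 to compound 3 (1.02 log units; beyond the scatter), a large step toward weaker inhibition. This position therefore responds strongly to what the chain carries, and this change runs against stronger inhibition. Nothing measured here accounts for the step. The compounds shown leave open whether the step follows the added chain length or the selenium-bearing end, which a longer chain ending in an amine would separate, and how a carboxylic acid here would read.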